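From Furan-2-yl to 2-Chlorophenyl on a Shared Core

A few compounds are considered here, and "the series" means these few. Any claim that something is new, unique, unknown or untested is made for them only; others in the source may bear on it.

In a functional assay on K562 cells (Homo sapiens) for cytotoxicity, read by ELISA, with a stated time of 4 days (a lower number here means a stronger inhibitor, a higher number a weaker inhibitor), compound 1 (`Cc1ccsc1-c1cc(-c2ccoc2)cc(-c2ccc(Cl)cc2)n1`) gives 19600 nM and compound 2 (`Clc1ccc(-c2cc(-c3ccoc3)cc(-c3ccco3)n2)s1`) gives 16200 nM as its result. Within the data shown here, these two values lie within the scatter of each other, so compound 2 stands level with compound 1, the only other compound measured so far. Compound 3 (`Clc1ccc(-c2cc(-c3ccoc3)cc(-c3ccccc3Cl)n2)s1`) has 2-chlorophenyl in place of furan-2-yl on an aromatic carbon, next to the ring nitrogen (2-chlorophenyl in place of furan-2-yl on an aromatic carbon). Compounds 1 and 2 differ in more than one place, so no measured single change can serve as a guide. With both values so close, no step beyond the scatter is expected, only a slight drift toward a lower number. The estimated change a 1.5-fold lower number from compound 2 to compound 3 (0.17 log units; within the scatter) stays small on that reading. The estimate for compound 3 is 11000 nM with an expected range from 3500 nM to 30000 nM once it is measured.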

Compound 3, half-maximal inhibitory concentration: 15800 nM
The estimate for compound 3 lay 1.4-fold (0.16 log units) below the measured number; measured number inside the range.
By their numbers in this assay, from the lowest: compounds 3, 2 and 1 (each within the scatter of the next).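

In this assay, among these compounds, setting 2-chlorophenyl in place of furan-2-yl on an aromatic carbon, next to the ring nitrogen, gives a 1.0-fold lower number from compound 2 to compound 3 (0.01 log units; within the scatter), and this is the first single change on the shared core that can be read. At this position, then, a five-membered aromatic ring with one hetero atom and a six-membered aromatic ring of carbon only leave compound 2 and compound 3 level, even though the entering group adds chlorine and loses the hydrogen-bond acceptor. Nothing measured alongside these compounds bears on why the two stand level.

From the compounds shown here alone, both groups at this position are uncharged aromatic rings, so it remains open whether an amine, a carboxylic acid or a longer alkyl chain on the same carbon would move the number beyond the scatter. Going by these compounds, it also remains open whether changing the furan-3-yl group would do so.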